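The source may hold more compounds than are shown below. What is called first, only, known or untested is meant among the compounds shown, and "the series" means these compounds.

Working notes on the series in a functional assay on HEL cells (Homo sapiens) for cytotoxicity, read by microscopy; a lower number here means that less compound is tolerated, a higher number that more compound is tolerated.

Two members have been measured. Compound 1, `CCCCCCCCCCc1cc2cn([C@H]3C[C@H](O)[C@@H](CO)O3)c(=O)nc2o1`, gives in this assay only a limit, > 50000 nM. Compound 2, `C=CCCCc1cc2cn([C@H]3C[C@H](O)[C@@H](CO)O3)c(=O)nc2o1`, likewise returns only a limit in this assay, > 200000 nM. Going by the values given here, compound 2 therefore stands nowhere on a numeric scale: its value is a limit, and the one other value shown is also a limit. The step that the two limits leave unreadable from compound 1 to compound 2 is unreadable because the limit of > 50000 nM in this assay, at which 1 of the 2 values shown sits, and the limit of > 200000 nM in this assay, at which 1 of the 2 values shown sits, bound both values; no size can be assigned to it, in either direction.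

Compound 3, `C=CCCCCCCc1cc2cn([C@H]3C[C@H](O)[C@@H](CO)O3)c(=O)nc2o1`, is not yet measured. It differs from compound 2 by pent-4-en-1-yl in place of vinyl on a saturated chain carbon, three bonds along the chain from an aromatic carbon. Among the compounds with values here, no measured step in this assay bears on this change with a readable size: the only step available is the unreadable one from compound 1 to compound 2. Both measured members sit at limits, so for compound 3 the expectation is again a limit rather than a number. The expected step is a number no higher from compound 2 to compound 3 (the limit leaves the size open). Compound 3 is estimated at 200000 nM, within 50000 nM to 500000 nM, most likely reported in this assay as a limit only.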

Compound 3, minimum cytotoxic concentration: > 200000 nM
Compound 3 ended at the assay's limit; the forecaster's own chance of this, stated with the estimate: 85%; the middle value sits exactly at the limit.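

Going by these compounds alone, compound 1, compound 2 and compound 3 all return only limits in this assay, so no step among them can be read, in size or in direction. The compounds shown leave open at what concentration, if any, each of them becomes cytotoxic, and whether the change of side chain on the shared core alters that concentration.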